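The source may report more compounds than this note shows. Statements on the series, on what has been measured and on what is new or still open speak of the compounds shown alone.

Of the compounds shown here, three sharing one core have been tested in a physicochemical assay, with a stated time of 6 min (on this read-out lower numbers stand for stronger inhibition and higher numbers for weaker inhibition), and they differ only in one group on an aromatic carbon. Compound 1 `O=C(Nc1ccc(F)cc1)Nc1nc(-c2cc3ccccc3o2)cs1` gives 1130 nM. Compound 2 `O=C(Nc1ccc(Br)cc1)Nc1nc(-c2cc3ccccc3o2)cs1` reached only a limit of the assay, > 200000 nM. Compound 3 `O=C(Nc1ccc([N+](=O)[O-])cc1)Nc1nc(-c2cc3ccccc3o2)cs1` gives 19300 nM, the higher of the two actual numbers. Its nearest neighbour is compound 1, and the gap is a 17-fold higher number from compound 1 to compound 3 (1.23 log units; beyond the scatter).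

Compound 4 `Cc1ccc(NC(=O)Nc2nc(-c3cc4ccccc4o3)cs2)cc1` has methyl in place of nitro on an aromatic carbon. For the measured compounds named here, no measured step makes this exact exchange, but three steps change the group at the same carbon. These are an at least 170-fold higher number from compound 1 to compound 2 (2.24 log units; beyond the scatter), a 17-fold higher number from compound 1 to compound 3 (1.23 log units; beyond the scatter) and an at least 10-fold lower number from compound 2 to compound 3 (1.01 log units; beyond the scatter). All three are large, so a large move cannot be ruled out, but they give no single direction for methyl. The expectation therefore stays close to compound 3 at 19300 nM, with a wide range. The expected change is a 1.3-fold higher number from compound 3 to compound 4 (0.11 log units; within the scatter), an estimate of no step beyond the scatter. For compound 4 the estimated value is 25000 nM, with an expected range from 3000 nM to 200000 nM.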

Compound 4, half-maximal inhibitory concentration: 500 nM
For compound 4 the middle estimate is 50-fold (1.70 log units) above the measured one; measured number below the stated range.
By their numbers in this assay, from the lowest: compound 4; then compound 1; then compound 3. At a limit, above all of these: compound 2.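

In this assay, for the compounds shown here, methyl is the first exchange at this carbon to lower the number relative to fluoro, a 2.3-fold lower number from compound 1 to compound 4 (0.35 log units; beyond the scatter), whereas bromo and nitro both raised it. The distance from nitro to methyl, a 39-fold lower number from compound 3 to compound 4 (1.59 log units; beyond the scatter), shows that the read-out at this carbon remains highly sensitive to the group present, and that compound 4 now sits below all the other compounds shown. The largest move, an at least 400-fold lower number from compound 2 to compound 4 (2.60 log units; beyond the scatter), is only a bound, resting on a limit rather than a number: the limit of > 200000 nM in this assay, at which 1 of the 4 values shown sits.

Going by these compounds, whether the lower number extends to a longer chain such as ethyl, or to a methoxy group or an amine at this carbon, remains open. On these data alone, it is also open whether methyl would keep its place in this order on a changed version of the shared core.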